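The source may hold more compounds than are shown below. What is called first, only, known or untested is meant among the compounds shown, and "the series" means these compounds.

Series notes. Compound 1 `CN1C(=S)[C@@H](NC(=O)c2nc(Cc3ccccc3)n(CCC(F)(F)F)n2)COc2ccccc21` carries a 3,3,3-trifluoropropyl group on an aromatic nitrogen of the shared core; in a functional assay on HT-29 cells (Homo sapiens) for inhibition, read by luminescence and CellTiter-Glo, with a stated time of 24 h (a higher number here means that more compound is needed for the effect, a lower number that less compound is needed), compound 1 gives 1550 nM. Compound 2 `CN1C(=S)[C@@H](NC(=O)c2nc(Cc3ccccc3)n(C3CCCC3)n2)COc2ccccc21`, with cyclopentyl in that position, gives 3530 nM, and compound 3 `CN1C(=S)[C@@H](NC(=O)c2nc(Cc3ccccc3)n(C3CCCCCC3)n2)COc2ccccc21`, with cycloheptyl, gives 5530 nM. Compound 1 thus stands lowest of the three, with compound 2 nearest and compound 3 furthest. Both changes away from the trifluoropropyl group raised the number: a 2.3-fold higher number from compound 1 to compound 2 (0.36 log units; beyond the scatter) and a 3.6-fold higher number from compound 1 to compound 3 (0.55 log units; beyond the scatter). The two rings differ little from each other, a 1.6-fold higher number from compound 2 to compound 3 (0.19 log units; within the scatter).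

Compound 4 `CN1C(=S)[C@@H](NC(=O)c2nc(Cc3ccccc3)n(C3CCOCC3)n2)COc2ccccc21` is not yet measured. Its change from compound 1 is oxan-4-yl in place of 3,3,3-trifluoropropyl on an aromatic nitrogen. The two measured steps that bear on it, from compound 1 to compound 2 and from compound 1 to compound 3, each replaced the same 3,3,3-trifluoropropyl group with a ring on that nitrogen and each gave a modest rise beyond the scatter. An oxan-4-yl ring is comparable in size to cyclopentyl and cycloheptyl, so for compound 4 a rise of similar size is expected: a 2.3-fold higher number from compound 1 to compound 4 (0.35 log units; beyond the scatter). Going by the values given here, the hydrogen-bond acceptor that enters has no measured counterpart here, which widens the range. Compound 4 is therefore estimated at 3500 nM, within 1500 nM to 8000 nM in this assay.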

Compound 4, half-maximal effective concentration: 2260 nM
The estimate for compound 4 lay 1.5-fold (0.19 log units) above the measured number, within the range that was stated.
By their numbers in this assay, from the lowest: compounds 1, 4, 2 and 3 (each within the scatter of the next, the first and the last beyond it).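

In this assay, going by these compounds alone, oxan-4-yl is the first ring on this aromatic nitrogen that cannot be told apart from the open 3,3,3-trifluoropropyl chain, with a 1.5-fold higher number from compound 1 to compound 4 (0.16 log units; within the scatter) against the steps beyond the scatter seen for the cyclopentyl and cycloheptyl rings, so the presence of a ring does not by itself separate a compound from compound 1. Among the ring-bearing compounds, the change to oxan-4-yl leaves compound 4 level with the cyclopentyl ring, with a 1.6-fold lower number from compound 2 to compound 4 (0.19 log units; within the scatter), but it does separate compound 4 from the cycloheptyl ring, with a 2.4-fold lower number from compound 3 to compound 4 (0.39 log units; beyond the scatter), and this is the only step among the three rings that lies beyond the scatter. No measurement in hand accounts for these differences.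

The compounds shown leave open whether an open chain without fluorine, such as propyl or a longer butyl chain, would stay level with compound 1, so the fluorine atoms and the chain cannot yet be separated. They also leave open how an amine in the six-membered ring, as in piperidin-4-yl, would compare with the oxygen of oxan-4-yl.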